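The source may hold more compounds than are shown below. What is called first, only, known or untested is meant among the compounds shown, and "the series" means these compounds.

Measured so far:
compound 1, `COc1cc(C(=O)N/N=C/c2ccccc2F)cc(OC)c1OC`: 76.5%
compound 2, `COc1cc(C2=NN(C(C)=O)C(c3ccc(F)cc3)O2)cc(OC)c1OC`: 13.3%
compound 3, `COc1cccc(/C=N/NC(=O)c2cc(OC)c(OC)c(OC)c2)c1OC`: 14.2%

In a functional assay on BGC-823 cells (Homo sapiens) for antiproliferative activity, read by MTT assay, tested at 5 uM (on this read-out lower numbers stand for a weaker effect and higher numbers for a stronger effect at the one concentration tested), compound 2 gives the lowest of the three numbers. Compound 3, at 14.2%, sits within the scatter of compound 2, whereas compound 1, at 76.5%, stands well above both, beyond the scatter.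

Compound 4, `COc1cc(C2=NN(C(C)=O)C(c3ccc(C(F)(F)F)cc3)O2)cc(OC)c1OC`, differs from compound 2 in one place: trifluoromethyl in place of fluoro on an aromatic carbon. For the measured compounds named here, no pair of measured compounds differs in a single place, so no measured step gauges this exchange; the two weak compounds 2 and 3 share the cyclised core and differ elsewhere.

For compound 4 the step of a number 2.7 percentage points higher from compound 2 to compound 4 (within the scatter) is expected to stay within the scatter, with no direction that can be called. Compound 4 is therefore estimated at 16%, in the range 4% to 34%.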

Compound 4, a percentage reported as inhibition, at one concentration (the size of the read-out at that concentration, not a potency): 3.4%
Beside the measured number, compound 4's estimate is 12.6 percentage points above it, and the stated range ends above it.
By their numbers in this assay, from the lowest: compounds 4, 2 and 3 (each within the scatter of the next, the first and the last beyond it); then compound 1.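

On the aromatic carbon para to a large group, the exchange of fluoro for trifluoromethyl now has its first measured step in this assay, a number a number 9.9 percentage points lower from compound 2 to compound 4 (within the scatter) and no more. Going from 1 heavy atom to 4 heavy atoms at this position therefore does not separate the two compounds on this read-out. No measurement shown bears on why.

On these data alone, whether an amine or a carboxylic acid on this aromatic carbon would carry the number beyond the scatter stays open. Also open, as far as these compounds go, is whether the same exchange reads alike on the core of compound 1.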